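The source may hold more compounds than are shown below. What is called first, only, known or untested is meant among the compounds shown, and "the series" means these compounds.

Compound 1 `COc1ccc(-c2ssc(=S)c2-c2cc(OC)c(OC)c(OC)c2)cc1O` gives 435 nM in a functional assay on KB cells (Homo sapiens) for antiproliferative activity, read by MTT assay, with a stated time of 72 h; on this read-out higher numbers stand for weaker inhibition and lower numbers for stronger inhibition. Compound 2 `COc1ccc(-c2ssc(=S)c2-c2cc(OC)c(OC)c(OC)c2)cc1[N+](=O)[O-]` returns only a limit of this assay, > 100000 nM, as noted in the limit of > 100000 nM in this assay, at which 1 of the 3 values shown sits. The step of an at least 220-fold higher number from compound 1 to compound 2 (2.36 log units; beyond the scatter) is made by the change (nitro in place of hydroxy on an aromatic carbon). Compound 3 `COc1ccc(-c2ssc(=O)c2-c2cc(OC)c(OC)c(OC)c2)cc1O` gives 460 nM; the difference between the core of compound 1 and the core of compound 3 is not broken down here, and their two values lie within the scatter of each other. Compound 4 `COc1ccc(-c2ssc(=O)c2-c2cc(OC)c(OC)c(OC)c2)cc1[N+](=O)[O-]` differs from compound 3 by nitro in place of hydroxy on an aromatic carbon, the same change at a place described in the same words. Given the step of an at least 220-fold higher number from compound 1 to compound 2 (2.36 log units; beyond the scatter) on the core of compound 1, compound 4 is expected to show a step of a 220-fold higher number from compound 3 to compound 4 (2.34 log units; beyond the scatter), most likely again reaching the limit of this assay. The estimate for compound 4 is 100000 nM, between 20000 nM and 400000 nM.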

Compound 4, half-maximal inhibitory concentration: 22300 nM
Compound 4: the middle estimate sits 4.5-fold (0.65 log units) above what was measured; the range from low to high includes it.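

In this assay, nitro in place of hydroxy also gives a large step on the second core: a 48-fold higher number from compound 3 to compound 4 (1.69 log units; beyond the scatter). The value of compound 2, > 100000 nM, is a limit of the assay and not a number. Across these two cores the direction of the change carries over but its size does not, and the two pairs alone give no reason for the gap: the same change on two cores in this assay, an at least 220-fold higher number (2.36 log units; beyond the scatter) from compound 1 to compound 2 and a 48-fold higher number (1.69 log units; beyond the scatter) from compound 3 to compound 4, at least 4.7-fold (0.67 log units) apart, beyond the scatter of two such steps

Only hydroxy and nitro are compared at this place on the aromatic ring. From the compounds shown here alone, how an amine or a carboxylic acid there would read in this assay, on either core, remains open.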